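This account rests on a few compounds, and the source may have more. Where it says the series, first, only, none or still open, it means among the compounds named here.

Measured so far:
- compound 1, `O=C(O)COc1ccc2nc(-c3cn(-c4ccc(O)cc4)nn3)ccc2c1` — in a physicochemical assay for solubility, read by spectrophotometry, using the shake flask method, with a stated time of 2 days, at pH 6.5 (on this read-out lower numbers stand for lower solubility and higher numbers for higher solubility), compound 1 gives 365 ug/mL
- compound 2, `COCCOCCOc1ccc2nc(-c3cn(-c4ccc(O)cc4)nn3)ccc2c1` — in this assay compound 2 gives 2.4 ug/mL

For the measured compounds named here, compound 1 stands highest of the two numbers; the only other value, that of compound 2, lies a 150-fold lower number from compound 1 to compound 2 (2.18 log units; beyond the scatter). Compound 3, `O=C(O)COc1ccc2nc(-c3cn(-c4ccccc4)nn3)ccc2c1`, differs from compound 1 by hydrogen in place of hydroxy on an aromatic carbon. Going by the values given here, the measured step concerns a change elsewhere on the shared core, so no measured step bears directly on this one. With a single atom removed, the carboxy group kept, only a small shift is expected, possibly none beyond the scatter. Compound 3 is therefore estimated at 200 ug/mL, between 60 ug/mL and 600 ug/mL. That estimate means an expected step of a 1.8-fold lower number from compound 1 to compound 3 (0.26 log units; within the scatter).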

Compound 3, solubility: 1050 ug/mL
Compound 3: the middle estimate sits 5.3-fold (0.72 log units) below what was measured; measured number outside the range, above it.
By their numbers in this assay, from the lowest: compound 2; then compound 1; then compound 3.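

Exchanging 4-hydroxyphenyl for phenyl brings a 2.9-fold higher number from compound 1 to compound 3 (0.46 log units; beyond the scatter) in this assay and so shows that this read-out also responds to a change at this place on the aromatic ring, not only to one on the chain. Here, with the carboxy group kept, losing the hydroxy raises the number rather than lowering it. Nothing measured here gives a reason for this rise. From the compounds shown here alone, whether the same step holds when the carboxy group is replaced remains open, as does what an amine or a methoxy group would give at this place.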